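This account rests on a few compounds, and the source may have more. Where it says the series, first, only, none or still open, it means among the compounds named here.

Of the compounds shown here, three built on one shared core have been tested in an assay on isolated protein for inhibition of aldehyde dehydrogenase 1A1 (Homo sapiens), read by spectrophotometry, tested at 10 uM; a lower number here means less inhibition, a higher number more inhibition at the concentration tested (going by the name of the read-out). Among the compounds with values here, compound 1 `Cc1cccc(Cn2c(CN3CCN(C(=O)c4ccc(C(C)C)cc4)CC3)nc3ccccc32)c1` gives 67.6%, and compound 3 `Cc1cccc(Cn2c(CN3CCN(C(=O)CC(C)C)CC3)nc3ccccc32)c1` gives 71.4%; the only measured step between compounds that differ in a single place, a number 3.8 percentage points higher from compound 1 to compound 3 (within the scatter), swaps the group on the carbonyl carbon and stays within the scatter. Compound 2 `O=C(C1CC1)N1CCN(Cc2nc3ccccc3n2Cc2ccccc2C(F)(F)F)CC1` gives 56.3%, the lowest of the three numbers: compound 1 stands beyond the scatter above it, and compound 3 further still.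

The unmeasured compound 4 `O=C(C1CC1)N1CCN(Cc2nc3ccccc3n2Cc2ccc(Cl)cc2)CC1` keeps the rest of compound 2 unchanged and alters the group at the other end of the molecule: 4-chlorophenyl in place of 2-(trifluoromethyl)phenyl on a saturated chain carbon bound to an aromatic nitrogen. Within the data shown here, no measured step touches this position, so nothing shows directly how the group on the saturated chain carbon bound to the aromatic nitrogen affects inhibition. Compounds 1 and 3 carry a different group there and give higher numbers than compound 2, but they also differ at the carbonyl carbon, so their values cannot be read as a step for this change alone. The expected step of a number 3.7 percentage points higher from compound 2 to compound 4 (within the scatter) is therefore an estimate of a small change of uncertain direction. Compound 4 is expected to give 60%, within a range from 42% to 78%.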

Compound 4, a percentage reported as inhibition, at one concentration (the size of the read-out at that concentration, not a potency): 56.6%
The estimate for compound 4 lay 3.4 percentage points above the measured number; measured number inside the range.
By their numbers in this assay, from the lowest: compounds 2 and 4 (each within the scatter of the next); then compounds 1 and 3 (each within the scatter of the next).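

Within the data shown here, compound 2 and compound 4 give the first direct reading of this position in this assay: exchanging the 2-(trifluoromethyl)phenyl group, on a saturated chain carbon bound to an aromatic nitrogen, for 4-chlorophenyl gives a number 0.3 percentage points higher from compound 2 to compound 4 (within the scatter). The group that leaves has 10 heavy atoms and the group that enters has 7, and the two also carry different substituents on their aromatic rings, yet this read-out at the single concentration tested does not tell the two compounds apart. No supporting data bear on why these two groups are not told apart.

Compound 1 and compound 3 each differ from compound 2 and compound 4 in more than one place, so the compounds shown do not reveal how much of the gap in their numbers belongs to this position and how much to the group on the carbonyl carbon. Also open, on these data alone, is how inhibition would respond if a group outside this small set, such as a pyridine ring or a plain methyl, stood on the same saturated chain carbon.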